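The compounds below may be only part of what the source reports. "The series", "measured", "known", "first", "only" and "open" are said of these compounds alone.

Measured so far:
Compound 1 `CC(C)(C)c1ccc(C(=O)N2CCC3(CC2)C(=O)N(CC(=O)N2CCCC(C(N)=O)C2)CN3c2ccccc2)cc1` gives 16900 nM in an assay on HEK293 cells for displacement of a labelled ligand from NPC1-like intracellular cholesterol transporter 1 (Homo sapiens); a lower number here means a stronger inhibitor, a higher number a weaker inhibitor.
Compound 2 `COC(=O)CCCNC(=O)CN1CN(c2ccccc2)C2(CCN(C(=O)c3ccc(C4CCCCC4)cc3)CC2)C1=O` gives 2500 nM in this assay.
Compound 3 `CC(C)(C)OC(=O)NC1CCN(C(=O)CN2CN(c3ccccc3)C3(CCN(C(=O)c4ccc(C5CCCCC5)cc4)CC3)C2=O)CC1` gives 4800 nM in this assay.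

Compound 2 carries the lowest number of the three. Its gap to compound 3 lies within the usual scatter, so no order between those two can be claimed; its gap to compound 1 lies beyond the scatter. Compound 4 `CC(C)(C)OC(=O)NCNC(=O)CN1CN(c2ccccc2)C2(CCN(C(=O)c3ccc(C4CCCCC4)cc3)CC2)C1=O` has not yet been measured. It differs from compound 2 in one place: (tert-butoxycarbonyl)amino in place of 2-(methoxycarbonyl)ethyl on a saturated chain carbon bound to an amide-type nitrogen. Among the measured compounds shown here, no measured pair shows this exact change, so the size of the step is open. Compound 3, which also carries a (tert-butoxycarbonyl)amino group, gives 4800 nM, a number within the scatter of compound 2, which points toward a modest step at most. Compound 4 is expected to give 4000 nM, with a range from 1500 nM to 12000 nM. The estimated step is a 1.6-fold higher number from compound 2 to compound 4 (0.20 log units; within the scatter), likely a slightly weaker inhibitor, close to the scatter.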

Compound 4, half-maximal inhibitory concentration: 1700 nM
Beside the measured number, compound 4's estimate is 2.4-fold (0.37 log units) above it; the measured number falls inside the stated range.
By their numbers in this assay, from the lowest: compounds 4, 2 and 3 (each within the scatter of the next, the first and the last beyond it); then compound 1.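

Putting (tert-butoxycarbonyl)amino in place of 2-(methoxycarbonyl)ethyl on a saturated chain carbon bound to an amide-type nitrogen gives a 1.5-fold lower number from compound 2 to compound 4 (0.17 log units; within the scatter) and so sets no order between the two compounds. This position therefore takes a group with more heavy atoms and one hydrogen-bond donor, with no readable change in this assay. Nothing available explains this outcome. Still open, going by these compounds, is whether a free amine or a carboxylic acid in place of these groups would shift the number beyond the scatter.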